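This account rests on a few compounds, and the source may have more. Where it says the series, first, only, none or still open, it means among the compounds named here.

Measured compounds in a functional assay on LNCaP cells (Homo sapiens) for cytotoxicity, read by MTT assay, with a stated time of 72 h; on this read-out lower numbers stand for stronger inhibition and higher numbers for weaker inhibition:
compound 1 `c1ccc2nc3c(cc2c1)Cn1c-3nc2ccccc21`: 11300 nM
compound 2 `Cc1ccc2cc3c(nc2c1)-c1nc2ccccc2n1C3`: 39000 nM
compound 3 `Cc1ccc2nc3c(cc2c1)Cn1c-3nc2ccccc21`: 62500 nM

Compound 2 stands second highest of the three numbers in this assay; its nearest neighbour is compound 3, within the scatter, and its furthest is compound 1, with a 3.5-fold higher number from compound 1 to compound 2 (0.54 log units; beyond the scatter) separating them. Compound 4 `COc1ccc2cc3c(nc2c1)-c1nc2ccccc2n1C3` differs from compound 2 by methoxy in place of methyl on an aromatic carbon. For the measured compounds named here, no measured step swaps methyl for methoxy. The two steps at hand, a 3.5-fold higher number from compound 1 to compound 2 (0.54 log units; beyond the scatter) and a 5.5-fold higher number from compound 1 to compound 3 (0.74 log units; beyond the scatter), both put methyl in place of hydrogen and both raise the number modestly; they say nothing direct about an oxygen-bearing substituent. The expected step, a 1.1-fold lower number from compound 2 to compound 4 (0.05 log units; within the scatter), is therefore taken as none beyond the scatter, with a wide range either way. Compound 4 is estimated at 35000 nM, between 12000 nM and 100000 nM.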

Compound 4, half-maximal inhibitory concentration: 25000 nM
The estimate for compound 4 lay 1.4-fold (0.15 log units) above the measured number, within the range that was stated.
By their numbers in this assay, from the lowest: compound 1; then compounds 4, 2 and 3 (each within the scatter of the next, the first and the last beyond it).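

In this assay methoxy in place of methyl on this aromatic carbon gives a 1.6-fold lower number from compound 2 to compound 4 (0.19 log units; within the scatter) and so does not separate the two groups. Methoxy in place of hydrogen gives a 2.2-fold higher number from compound 1 to compound 4 (0.34 log units; beyond the scatter) and so, like methyl here, leaves the number higher than that of the unsubstituted core. No measurement at hand offers an explanation for these steps.

As far as these compounds go, whether an amine, a carboxylic acid or a longer chain on this carbon would return the number towards that of compound 1 stays open. From the compounds shown here alone, how methoxy would behave at the carbon that carries methyl in compound 3 also stays open.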